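The source may report more compounds than this note shows. Statements on the series, on what has been measured and on what is new or still open speak of the compounds shown alone.

The study concerns two measured compounds and one still awaiting measurement, all built on a shared core. Compound 1 `CC(C)c1ccccc1-c1nccc(NCc2ccc(-c3cccnc3)cc2)n1` is the plainer of the measured pair; in an assay on a protein complex for inhibition of ubiquitin carboxyl-terminal hydrolase 1/WD repeat-containing protein 48 (Homo sapiens), read by fluorescence (a higher number here means a weaker inhibitor, a lower number a stronger inhibitor), compound 1 gives 150 nM. Compound 2 `Cc1cnc(-c2ccccc2C(C)C)nc1NCc1ccc(-c2cccnc2)cc1` carries a methyl in place of hydrogen on an aromatic carbon, and in this assay compound 2 gives 70 nM. Among the compounds with values here, the single measured step, a 2.1-fold lower number from compound 1 to compound 2 (0.33 log units; beyond the scatter), is modest yet beyond the scatter, so compound 2 stands as the lower of the two numbers, with compound 1 as its only neighbour.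

Compound 3 `Cc1cnc(-c2ccccc2C(C)C)nc1NCc1ccc(-c2nnn[nH]2)cc1` is unmeasured. It differs from compound 2 in one place: 1H-tetrazol-5-yl in place of pyridin-3-yl on an aromatic carbon. Within the data shown here, no measured step concerns this kind of exchange; the only step at hand, a 2.1-fold lower number from compound 1 to compound 2 (0.33 log units; beyond the scatter), touches the methyl and says nothing about swapping one ring for another. With nothing to lean on, the direction is open, and the step is expected to be small but uncertain, a 2.9-fold higher number from compound 2 to compound 3 (0.46 log units; beyond the scatter). Compound 3 is therefore estimated at 200 nM in this assay, within a wide band from 40 nM to 1000 nM.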

Compound 3, half-maximal inhibitory concentration: 5900 nM
For compound 3 the middle estimate is 30-fold (1.47 log units) below the measured one; measured number outside the range, above it.
By their numbers in this assay, from the lowest: compound 2; then compound 1; then compound 3.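

At the aromatic carbon para to a large group, the ring attached there clearly matters in this assay: 1H-tetrazol-5-yl in place of pyridin-3-yl gives an 84-fold higher number from compound 2 to compound 3 (1.93 log units; beyond the scatter), a large step that far exceeds the modest one seen with the methyl, a 2.1-fold lower number from compound 1 to compound 2 (0.33 log units; beyond the scatter). The exchange alters several features at once, replacing a six-membered aromatic ring with 1 hetero atom and 0 hydrogen-bond donors by a five-membered aromatic ring with 4 hetero atoms and 1 hydrogen-bond donor, so this single step cannot assign the weaker inhibition to any one of those features. Nothing available bears on the reason for this loss.

The compounds shown leave open which of these features carries the step, and a plain phenyl ring, a 1-methyltetrazol-5-yl group or a carboxylic acid at the same place would help to separate them. They also leave open whether the tetrazole exchange would give a step of similar size on the core of compound 1, which lacks the methyl.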